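This account rests on a few compounds, and the source may have more. Where it says the series, first, only, none or still open, it means among the compounds named here.

Measured so far in a functional assay on the whole organism with Mus musculus as the target, with a stated time of 0.5 h; on this read-out higher numbers stand for an effect only at larger amounts of compound and lower numbers for an effect already at smaller amounts: compound 1, `O=C1OC2(c3ccccc3)CCCCCN1C2=O`, gives 45 mg/kg. Compound 2, `CC[C@]1(c2ccccc2)OC(=O)N(C)C1=O`, gives 69 mg/kg. For compound 3, `O=C1O[C@]2(c3ccccc3)CCCCCN1C2=O`, only a limit of the assay is known, < 400 mg/kg.

Among the numbers shown, compound 2 and compound 1 sit within the scatter of each other, so neither stands apart. Compound 4, `CC[C@@]1(c2ccccc2)OC(=O)N(C)C1=O`, differs from compound 2 in a single place: the two compounds have the same atoms and bonds and differ only in configuration as drawn: 1 of 1 stereo elements differ; a stereocentre at a saturated ring carbon is drawn R in compound 2 and S in compound 4. Among the compounds with values here, the one measured step of the same kind is a step that the limit leaves unreadable from compound 1 to compound 3, which cannot be read because of the limit of < 400 mg/kg in this assay, at which 1 of the 3 values shown sits, and because of the fact that one of compounds 1 and 3 is drawn with a defined configuration and the other without, at the place where they differ. No direction can be taken from it. Compound 4 is therefore expected to stand near compound 2, with an estimated step of a 1.2-fold higher number from compound 2 to compound 4 (0.06 log units; within the scatter). The estimate for compound 4 is 80 mg/kg, between 30 mg/kg and 300 mg/kg.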

Compound 4, dose for half-maximal effect: 64 mg/kg
Compound 4: middle estimate off by 1.3-fold (0.10 log units), on the high side; low and high end bracket the measured number.
By their numbers in this assay, from the lowest: compounds 1, 4 and 2 (each within the scatter of the next).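

Going from R to S at this saturated ring carbon gives a 1.1-fold lower number from compound 2 to compound 4 (0.03 log units; within the scatter) in this assay and so shows that, for this pair, the drawn configuration makes no readable difference. Within the data shown here, it is the first readable step of this kind, since the earlier step between compound 1 and compound 3 cannot be read. From the compounds shown here alone, whether the same holds in the core of compound 1 stays open. So does whether the two forms would still match if the shared core carried an amine, a carboxylic acid or a longer chain.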